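Ring Swap on a Weak Nucleoside Analogue

This account rests on a few compounds, and the source may have more. Where it says the series, first, only, none or still open, it means among the compounds named here.

compound 1 `COc1ncnc2c1c(-c1ccco1)cn2[C@@H]1O[C@H](CO)[C@@H](O)[C@H]1O` — 100 nM
compound 2 `O=c1[nH]cnc2c1c(-c1ccsc1)cn2[C@@H]1O[C@H](CO)[C@@H](O)[C@H]1O` — 12000 nM

Of the compounds shown here, two have been measured so far. In a functional assay on HL-60 cells (Homo sapiens) for antiproliferative activity, read by XTT assay, with a stated time of 72 h (a lower number here means a stronger inhibitor, a higher number a weaker inhibitor), compound 1 gives 100 nM. In this assay compound 2 gives 12000 nM; compound 2 therefore stands with the highest number of the two, and its gap to compound 1 lies well beyond the usual scatter. Compound 1 and compound 2 differ in more than one place, so their two values alone say nothing about any single change.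

Compound 3 `O=c1[nH]cnc2c1c(-c1ccco1)cn2[C@@H]1O[C@H](CO)[C@@H](O)[C@H]1O` has not yet been measured. It is reached from compound 2 by one change: furan-2-yl in place of thiophen-3-yl on an aromatic carbon. Among the compounds with values here, no pair of measured compounds shows this change in isolation, so the size of the step must be guessed rather than read off.

Compound 3 is expected to show a step of a 2.4-fold lower number from compound 2 to compound 3 (0.38 log units; beyond the scatter) that is only modest, at or slightly beyond the scatter, in the direction of a lower number. On that basis compound 3 is estimated to give about 5000 nM in this assay, with a likely range from 1000 nM to 20000 nM. The measurement will tell whether that holds.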

Compound 3, half-maximal inhibitory concentration: 2200 nM
For compound 3 the middle estimate is 2.3-fold (0.36 log units) above the measured one, within the range that was stated.
By their numbers in this assay, from the lowest: compound 1; then compound 3; then compound 2.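

Within the data shown here, with everything else on the molecule held fixed, furan-2-yl in place of thiophen-3-yl gives a 5.5-fold lower number from compound 2 to compound 3 (0.74 log units; beyond the scatter) in this assay and so shows for the first time that this aromatic carbon, two ring bonds from the ring nitrogen, responds to which ring it carries. The two groups match in heavy-atom count, in ring size and in their counts of hydrogen-bond donors and acceptors, and neither carries a net charge, so the step appears with none of these counts changing. Nothing measured here explains the step.

The names of the two groups show that both the hetero atom and the point of attachment differ, and only thiophen-2-yl or furan-3-yl at this carbon would separate the two. Also open is whether the same swap holds on the core of compound 1, since compound 3 gives 2200 nM in this assay while compound 1 gives 100 nM with the same furan-2-yl, and no thiophen-3-yl partner of compound 1 is shown.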